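The compounds below may be only part of what the source reports. "The series", "measured", "known", "first", "only" and "open" are said of these compounds alone.

Measured compounds:
- Compound 2 `Cc1[nH]c(=O)n(C)c1-c1ccc(CC(C)C)cc1`: 7800 nM
- Compound 3 `CCCCCCCCc1ccc(-c2c(C)[nH]c(=O)n2C)cc1`: 19400 nM
- Compound 1 `CCCCc1ccc(-c2c(C)[nH]c(=O)n2C2CCCCC2)cc1`: 27100 nM

In a functional assay on brain (Rattus norvegicus, strain Wistar) for inhibition (on this read-out lower numbers stand for stronger inhibition and higher numbers for weaker inhibition), compound 2 gives 7800 nM, the lowest number of the three. Compound 3 gives 19400 nM and compound 1 gives 27100 nM. Among the measured compounds shown here, the one single-point step among them is a 2.5-fold higher number from compound 2 to compound 3 (0.40 log units; beyond the scatter), a modest weakening when the chain is lengthened.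

Compound 4 `Cc1[nH]c(=O)n(C)c1-c1ccc(-c2ccccc2)cc1` has not been measured. Its difference from compound 2 is phenyl in place of isobutyl on an aromatic carbon

For the measured compounds named here, only the step from compound 2 to compound 3 bears on this, and it concerns a longer chain, not a ring; no measured pair shows a phenyl entering at this position. That one step shows that enlarging this group gave a higher number, so a phenyl is expected to give at most a modest change, most likely toward a higher number, possibly none beyond the scatter. Compound 4 is therefore expected to give 11000 nM (range 3500 nM to 35000 nM), which would mean an expected step of a 1.4-fold higher number from compound 2 to compound 4 (0.15 log units; within the scatter).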

Compound 4, half-maximal inhibitory concentration: 6300 nM
Compound 4: middle estimate off by 1.7-fold (0.24 log units), on the high side; the range from low to high includes it.
By their numbers in this assay, from the lowest: compounds 4 and 2 (each within the scatter of the next); then compounds 3 and 1 (each within the scatter of the next).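

In this assay, putting phenyl in place of isobutyl on this aromatic carbon gives a 1.2-fold lower number from compound 2 to compound 4 (0.09 log units; within the scatter), so this position accepts a six-membered aromatic ring of carbon only, with more heavy atoms than isobutyl, without a change beyond the scatter. The earlier step, a 2.5-fold higher number from compound 2 to compound 3 (0.40 log units; beyond the scatter), came with a longer saturated chain, so a larger group at this position does not by itself go with a higher number; compound 4 goes against that reading, and compound 3 alone fits it. Nothing shown explains why the ring and the longer chain differ here.

As far as these compounds go, whether phenyl carrying an amine or a carboxylic acid would leave the number unchanged remains open. So does whether a pyridine ring or a cyclohexyl group at this position would match phenyl.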